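Trading a Benzyl for a Spiro Amine: Solubility Outlook

The source may hold more compounds than are shown below. What is called first, only, known or untested is meant among the compounds shown, and "the series" means these compounds.

Of the compounds shown here, two have been measured so far. Compound 1 `COc1ccc2[nH]c(C(=O)N3CC(=O)N(Cc4ccccc4)[C@@H](CCc4ccccc4)C3)cc2c1` and compound 2 `COc1ccc2[nH]c(C(=O)N3CC(=O)N(Cc4cccc(OC(F)F)c4)[C@@H](CN4CC5CCC4C5)C3)cc2c1` were both tested in a physicochemical assay for solubility, read by spectrophotometry, in phosphate buffer, with a stated time of 2 h, at pH 7.4; a higher number here means a more soluble compound, a lower number a less soluble compound. Compound 1 gives 4400 nM, the lower of the two numbers, while compound 2 gives 62000 nM, a gap beyond the scatter. Compound 3 `COc1ccc2[nH]c(C(=O)N3CC(=O)N(Cc4ccccc4)[C@@H](CN4CCC5(CCCC5)CC4)C3)cc2c1` is not yet measured. It differs from compound 1 by a group of 10 heavy atoms (9 carbon, 1 nitrogen; one five-membered non-aromatic ring of carbon only, one six-membered non-aromatic ring with 1 hetero atom) in place of a group of 7 heavy atoms (7 carbon; one six-membered aromatic ring of carbon only), on a saturated chain carbon bound to a saturated ring carbon. For the measured compounds named here, no measured pair of exactly this kind exists, so the size of the step is uncertain. Compound 3 is expected to show a rise from compound 1 of a 6.8-fold higher number from compound 1 to compound 3 (0.83 log units; beyond the scatter). In this assay compound 3 is estimated at 30000 nM, within a range from 8000 nM to 110000 nM.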

Compound 3, solubility: 5000 nM
Estimate against measurement, compound 3: 6.0-fold (0.78 log units) above; the measured number lies below the stated range.
By their numbers in this assay, from the lowest: compounds 1 and 3 (each within the scatter of the next); then compound 2.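

In this assay, putting the group of 10 heavy atoms in place of benzyl on a saturated chain carbon bound to a saturated ring carbon gives a 1.1-fold higher number from compound 1 to compound 3 (0.06 log units; within the scatter) and so leaves the two compounds within the scatter. Trading the aromatic ring for two non-aromatic rings, one of them holding the hetero atom, therefore does not by itself separate compound 3 from compound 1 here. No measurement at hand bears on why this is so.

A morpholine or a carboxylic acid on that same carbon remains an open case.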